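This account rests on a few compounds, and the source may have more. Where it says the series, first, only, none or still open, it means among the compounds named here.

Compound 1 `O=C(c1ccccc1C(F)(F)F)N(/N=N/c1ccc([N+](=O)[O-])cc1Br)c1ccc([N+](=O)[O-])cc1Br`: 13300 nM
Compound 2 `O=C(c1ccccc1)N(/N=N/c1ccc([N+](=O)[O-])cc1C(F)(F)F)c1ccc([N+](=O)[O-])cc1C(F)(F)F`: 600 nM

Both were tested in a functional assay on HeLa cells (Homo sapiens) for cytotoxicity, read by MTT assay, with a stated time of 72 h; on this read-out higher numbers stand for weaker inhibition and lower numbers for stronger inhibition. Compound 1 gives 13300 nM, and compound 2 gives 600 nM, the lower of the two numbers; the gap between them is beyond the scatter, but the two structures differ in several places at once, so no single step can be read from that pair. Compound 3 `O=C(c1ccc(C(F)(F)F)cc1)N(/N=N/c1ccc([N+](=O)[O-])cc1C(F)(F)F)c1ccc([N+](=O)[O-])cc1C(F)(F)F` has not yet been measured. It differs from compound 2 in one place: trifluoromethyl in place of hydrogen on an aromatic carbon. For the measured compounds named here, no measured pair shows this change on its own, so its direction is open from the data at hand. Compound 3 is expected to stay close to compound 2, with a step of a 1.2-fold higher number from compound 2 to compound 3 (0.07 log units; within the scatter) that is not expected to go beyond the scatter. The estimate for compound 3 in this assay is 700 nM, with a range from 250 nM to 2500 nM.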

Compound 3, half-maximal inhibitory concentration: 690 nM
Compound 3: the middle estimate sits 1.0-fold (0.01 log units) above what was measured; the range from low to high includes it.
By their numbers in this assay, from the lowest: compounds 2 and 3 (each within the scatter of the next); then compound 1.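

In this assay, for the compounds shown here, the change from phenyl to 4-(trifluoromethyl)phenyl gives a 1.2-fold higher number from compound 2 to compound 3 (0.06 log units; within the scatter), the only step in this set that can be read at a single place. This aromatic carbon, para to a large group, therefore carries trifluoromethyl, with its 4 heavy atoms, in place of hydrogen while the two compounds remain within the scatter of each other. Nothing measured here explains why the two compounds read alike.

As far as these compounds go, whether an amine, a carboxylic acid or a longer chain at this same carbon would also stay within the scatter remains open. Compound 1 carries trifluoromethyl at another place on this ring, but it also differs from compound 2 and compound 3 elsewhere, so the effect of that placement cannot be read.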